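Hydroxy to methoxy on the anilino ring of compound 2

A few compounds are considered here, and "the series" means these few. Any claim that something is new, unique, unknown or untested is made for them only; others in the source may bear on it.

Within the data shown here, compound 2 `O=C(/C=C\Nc1ccc(O)cc1)c1cn(-c2ccccc2)nc1-c1ccccc1` gives the lowest of the two numbers measured so far: in a functional assay on U-87MG ATCC cells (Homo sapiens) for antiproliferative activity, read by MTT assay, with a stated time of 48 h (on this read-out lower numbers stand for stronger inhibition and higher numbers for weaker inhibition), compound 2 gives 4290 nM. Its nearest neighbour is compound 1 `O=C(/C=C\Nc1ccc(F)cc1)c1cn(-c2ccccc2)nc1-c1ccccc1`, which in this assay gives 10200 nM; the step of a 2.4-fold lower number from compound 1 to compound 2 (0.38 log units; beyond the scatter) is the only one in hand and concerns hydroxy in place of fluoro on an aromatic carbon.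

Compound 3 `COc1ccc(N/C=C\C(=O)c2cn(-c3ccccc3)nc2-c2ccccc2)cc1` differs from compound 2 by methyl in place of hydrogen on an oxygen on an aromatic ring, that is, hydroxy to methoxy on the (4-hydroxyphenyl)amino group. Among the measured compounds shown here, no measured step covers a hydroxy-to-methoxy exchange; the step from compound 1 to compound 2 shows only that this ring position moves the number beyond the scatter, not in which direction a methyl on the oxygen would push it.

Accordingly, compound 3 is expected to give 6500 nM, with a range of 2200 nM to 19000 nM, the estimated step of a 1.5-fold higher number from compound 2 to compound 3 (0.18 log units; within the scatter) being modest and of uncertain direction.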

Compound 3, half-maximal inhibitory concentration: > 50000 nM
Compound 3: a limit, no number (the forecaster's own chance of this, stated with the estimate: 5%); middle value at least 7.6-fold (0.88 log units) from the limit.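

In this assay compound 3 gives > 50000 nM, which is a limit of the assay and not a number: the limit of > 50000 nM in this assay, at which 1 of the 3 values shown sits.

Among these compounds, the direction left unsettled by the earlier compounds is now fixed: methyl on the oxygen gives an at least 11-fold higher number from compound 2 to compound 3 (1.06 log units; beyond the scatter), and methoxy in place of fluoro on the same aromatic carbon gives an at least 4.9-fold higher number from compound 1 to compound 3 (0.69 log units; beyond the scatter). Across the three compounds, the number at this ring position thus rises from hydroxy through fluoro to methoxy, with each listed step beyond the scatter.

As far as these compounds go, how far compound 3 lies past its limit stays open, and with it the true size of both new steps. Also open, from the compounds shown here alone, is whether an amine or a carboxylic acid on this aromatic carbon would keep the number of compound 2, and whether a longer chain on the oxygen would behave as methyl does.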